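Trifluoromethyl Added to the Phenyl of Compound 1

This account rests on a few compounds, and the source may have more. Where it says the series, first, only, none or still open, it means among the compounds named here.

Compound 1 `O=C(O)Cc1sc(C(c2ccccc2)c2ccccc2)nc1-c1ccccc1` gives 80% in an in vitro functional assay on HEK285-7 cells for antagonist activity at prostaglandin D2 receptor 2 (Homo sapiens), read by BRET and beta-arrestin recruitment; a higher number here means a larger maximal response, a lower number a smaller maximal response. Compound 2 `O=C(O)Cc1sc(C(c2ccc(F)cc2)c2ccc(F)cc2)nc1-c1cc(F)cc(F)c1` gives 80% in this assay, so compound 1 stands level with compound 2 at the digits shown, within the scatter. Compound 3 `O=C(O)Cc1sc(C(c2ccccc2)c2ccccc2)nc1-c1ccc(C(F)(F)F)cc1` differs from compound 1 by trifluoromethyl in place of hydrogen on an aromatic carbon. Going by the values given here, no measured pair shows this change; because compound 2 with fluorine on every ring still gives 80%, only a small step, none beyond the scatter, is expected. Compound 3 is expected to give 80% in this assay, between 65% and 92%. The estimated step is no change at the digits printed from compound 1 to compound 3 (within the scatter).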

Compound 3, largest response reached (reported as efficacy), in percent of the reference or control that the assay uses: 80%
For compound 3 middle estimate and measured number coincide at the digits printed, within the range that was stated.
By their numbers in this assay, from the lowest: compounds 1, 2 and 3 (each within the scatter of the next).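

In this assay, trifluoromethyl in place of hydrogen on an aromatic carbon, para to a large group, gives no change at the digits printed from compound 1 to compound 3 (within the scatter) at this position. The two compounds differ in one place only, so this reading belongs to the change from phenyl to 4-(trifluoromethyl)phenyl alone, and that change, which adds four heavy atoms, leaves the maximal response unmoved. Nothing measured here offers an explanation for this result. As far as these compounds go, whether an amine or a nitrile on the same carbon would leave the response equally unmoved stays open, as does the outcome of trifluoromethyl on another carbon of this ring.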